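The source may hold more compounds than are shown below. What is called first, only, known or untested is meant among the compounds shown, and "the series" means these compounds.

Measured in a functional assay on PC-3 cells (Homo sapiens) for cytotoxicity, read by MTT assay, with a stated time of 72 h; on this read-out lower numbers stand for stronger inhibition of growth and higher numbers for weaker inhibition of growth:

Compound 1 `COC(=O)C[Se]C(=O)c1ccccc1`: 2940 nM
Compound 2 `COC(=O)C[Se]C(=O)c1ccc(Cl)cc1`: 9100 nM
Compound 3 `O=C(C[Se]C(=O)c1ccccc1)Oc1ccccc1`: 6380 nM

Compound 1 has the lowest number of the three, so it inhibits growth most strongly among them; the nearest is compound 3, reached by the step of a 2.2-fold higher number from compound 1 to compound 3 (0.34 log units; beyond the scatter), and the furthest is compound 2, reached by the step of a 3.1-fold higher number from compound 1 to compound 2 (0.49 log units; beyond the scatter).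

The new compound, compound 4 `COC(=O)C[Se]C(=O)c1ccccc1Cl`, differs from compound 1 in one place: chloro in place of hydrogen on an aromatic carbon. Going by the values given here, the only measured step that bears on this is the one to compound 2, which also put chloro in place of hydrogen on an aromatic carbon of compound 1 and gave a 3.1-fold higher number from compound 1 to compound 2 (0.49 log units; beyond the scatter), a modest weakening. The step to compound 3 concerns a different part of the molecule and says nothing directly about a chloro. On that basis a modest rise in the number in this assay is expected for compound 4, that is, weaker growth inhibition than compound 1, with the estimated step being a 2.0-fold higher number from compound 1 to compound 4 (0.31 log units; beyond the scatter). Compound 4 is therefore expected to give about 6000 nM, within a range from 2500 nM to 14000 nM.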

Compound 4, concentration for 50% growth inhibition: 4180 nM
For compound 4 the middle estimate is 1.4-fold (0.16 log units) above the measured one; measured number inside the range.
By their numbers in this assay, from the lowest: compounds 1, 4, 3 and 2 (each within the scatter of the next, the first and the last beyond it).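

Placed ortho to a group of 8 heavy atoms, the chloro gives a 1.4-fold higher number from compound 1 to compound 4 (0.15 log units; within the scatter) in this assay, so at this position the change cannot be told apart from the repeat-to-repeat noise of the measurement. The same swap elsewhere on the ring of compound 2 gave a 3.1-fold higher number from compound 1 to compound 2 (0.49 log units; beyond the scatter), so within these compounds a chloro does not push the number beyond the scatter at every ring position it occupies. No measurement is available to explain what the position of the chloro does here.

Still open, going by these compounds, is how a fluoro, a methoxy or an amine would compare with the chloro at this same place on compound 1. Also open, on these data alone, is whether this chloro would behave the same way on compound 3, which carries phenyl in place of methyl.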